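From hydroxy to methoxy: what compound 3 may show

This account rests on a few compounds, and the source may have more. Where it says the series, first, only, none or still open, it means among the compounds named here.

In an ADME assay on BJ cells (Homo sapiens) for cytotoxicity, with a stated time of 72 h (a higher number here means that more compound is needed for the effect, a lower number that less compound is needed), compound 2 `Cc1cc(NC(=O)Nc2ccc(O)cc2)c2ccccc2n1` gives > 25000 nM, which is a limit of the assay and not a number. Its close relative, compound 1 `COC(=O)c1ccc(NC(=O)Nc2cc(C)nc3ccccc23)cc1`, gives 21000 nM in this assay. For the measured compounds named here, the only measured step, hydroxy in place of methoxycarbonyl on an aromatic carbon, is an at least 1.1-fold higher number from compound 1 to compound 2 (0.07 log units; that floor lies within the scatter).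

Compound 3 `COc1ccc(NC(=O)Nc2cc(C)nc3ccccc23)cc1` differs from compound 2 by methyl in place of hydrogen on an oxygen on an aromatic ring, that is, hydroxy to methoxy: methyl in place of hydrogen on an oxygen on an aromatic ring. The measured step changed the group at this same place, yet it gives only a floor within the scatter, an at least 1.1-fold higher number from compound 1 to compound 2 (0.07 log units; that floor lies within the scatter). As far as these compounds go, no change beyond the scatter is therefore expected in this assay, and the direction stays open. The expected change is an at least 1.1-fold lower number from compound 2 to compound 3 (0.05 log units; that floor lies within the scatter). For compound 3 the estimated value is 22000 nM, with an expected range from 10000 nM to 40000 nM.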

Compound 3, half-maximal effective concentration: > 25000 nM
Compound 3: a limit, no number; the forecaster's own chance of this, stated with the estimate: 45%; middle value at least 1.1-fold (0.05 log units) from the limit.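

Compound 2 and compound 3 both stand at a limit in this assay, so the step between them, methyl in place of hydrogen on the oxygen, cannot be read. For the compounds shown here, the one step that can be read is a second comparison with compound 1: an at least 1.1-fold higher number from compound 1 to compound 3 (0.07 log units; that floor lies within the scatter). Like the step to hydroxy, it gives only a floor within the scatter, so at this place neither hydroxy nor methoxy can be told apart from methoxycarbonyl, and most of what is shown rests on one limit: the limit of > 25000 nM in this assay, at which 2 of the 3 values shown sit.

As far as these compounds go, whether compound 2 and compound 3 truly differ in this assay stays open. Also open, from the compounds shown here alone, is what an amine or a carboxylic acid at this place would give, and whether either would bring a number clearly lower than that of compound 1.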